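The compounds below may be only part of what the source reports. "The series", "measured", "known", "first", "only" and "open" are said of these compounds alone.

Compounds in this set share one core and differ in the group on an amine nitrogen. In a functional assay on MCF7 cells (Homo sapiens) for inhibition, read by sulforhodamine B assay (on this read-out lower numbers stand for stronger inhibition and higher numbers for weaker inhibition), compound 1 `CCc1ccc(NC2=CC(=O)c3c(nc4n3[C@H]3OC[C@@H](O)[C@H]3OC4)C2=O)cc1`, with 4-ethylphenyl, gives 8990 nM, while compound 2 `COc1cccc(NC2=CC(=O)c3c(nc4n3[C@H]3OC[C@@H](O)[C@H]3OC4)C2=O)c1`, with 3-methoxyphenyl, gives 3830 nM. Exchanging these two groups thus produces a 2.3-fold lower number from compound 1 to compound 2 (0.37 log units; beyond the scatter).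

Compound 3 `O=C1C(NCc2ccccc2)=CC(=O)c2c1nc1n2[C@H]2OC[C@@H](O)[C@H]2OC1`, with benzyl, stands at > 8000 nM, which is a limit of the assay and not a number.

Compound 4 `O=C1C(Nc2cccc(Cl)c2)=CC(=O)c2c1nc1n2[C@H]2OC[C@@H](O)[C@H]2OC1` has not yet been measured. Its difference from compound 3 is 3-chlorophenyl in place of benzyl on an amine nitrogen. In words, this is 3-chlorophenyl in place of benzyl on an amine nitrogen.

The closest guide is an at least 2.0-fold higher number from compound 2 to compound 3 (0.31 log units; beyond the scatter), where benzyl replaced 3-methoxyphenyl. The present change leaves benzyl instead, so a modest fall in the number is expected in this assay. The remaining measured step is a step that the limit leaves unreadable from compound 1 to compound 3, and it offers no size to work from.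

The expected result is an at least 2.0-fold lower number from compound 3 to compound 4 (0.30 log units; that floor lies within the scatter). Compound 4 is estimated at 4000 nM, within an expected range of 1600 nM to 10000 nM.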

Compound 4, half-maximal inhibitory concentration: 2970 nM
Beside the measured number, compound 4's estimate is 1.3-fold (0.13 log units) above it; measured number inside the range.
By their numbers in this assay, from the lowest: compounds 4 and 2 (each within the scatter of the next); then compound 1.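

Compound 3 stands at a limit of the assay, not at a number: the limit of > 8000 nM in this assay, at which 1 of the 4 values shown sits. Even so, this assay gives an at least 2.6-fold lower number from compound 3 to compound 4 (0.43 log units; beyond the scatter), which shows that 3-chlorophenyl on this amine nitrogen reads clearly better than benzyl, whereas the earlier benzyl comparison involved only 3-methoxyphenyl. Chloro in place of methoxy gives a 1.3-fold lower number from compound 2 to compound 4 (0.11 log units; within the scatter), so these two groups are not separated, while 3-chlorophenyl in place of 4-ethylphenyl gives a 3.0-fold lower number from compound 1 to compound 4 (0.48 log units; beyond the scatter).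

The step from compound 1 to compound 3 cannot be read, since it ends at the limit. The compounds shown also leave open whether the gap between compound 1 and compound 4 comes from the ring position or the group itself, which 4-chlorophenyl or 3-ethylphenyl on the same nitrogen would help to separate.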